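Swapping a Carboxyphenyl for a Carboxybenzyl on the Amide

The source may report more compounds than this note shows. Statements on the series, on what has been measured and on what is new or still open speak of the compounds shown alone.

Measured compounds in an assay on isolated protein for binding affinity to P-selectin (Homo sapiens), read by ELISA, tested at 500 uM; on this read-out lower numbers stand for less inhibition and higher numbers for more inhibition at the one concentration tested (going by the name of the read-out):
- compound 1 `CCCCCCCCCCOc1cccc(OCCCCCC(=O)N(Cc2ccc(C(=O)OC)cc2)c2ccc(C(=O)OC)cc2)c1` gives 78%
- compound 2 `CCCCCCCCCCOc1cc(OCCCCCCCCCC)cc(OCCCCCCON=C(c2ccc(C(=O)O)cc2)c2ccc(C(=O)O)cc2)c1` gives 2%
- compound 3 `CCCCCCCCCCOc1cc(OCCCCCCCCCC)cc(OCCCCCC(=O)N(c2cccc(C(=O)O)c2)c2cccc(C(=O)O)c2)c1` gives 20%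

Compound 3 stands second highest of the three numbers. Its nearest neighbour is compound 2, whose number is lower by a gap beyond the usual scatter of this assay. Compound 1 lies furthest away, with a number higher than compound 3 by a gap that is also beyond the scatter.

The step to compound 4 `CCCCCCCCCCOc1cc(OCCCCCCCCCC)cc(OCCCCCC(=O)N(Cc2ccc(C(=O)O)cc2)c2cccc(C(=O)O)c2)c1` changes one thing on the shared core of compound 3: 4-carboxybenzyl in place of 3-carboxyphenyl on an amide-type nitrogen. For the measured compounds named here, no measured pair among the three compounds shows this single change on its own, so the size of the step cannot be read from data already in hand. Going by the values given here, compound 1, the only compound carrying a benzyl group on the amide-type nitrogen, also differs in other places, so its high number cannot be tied to that group alone.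

The step from compound 3 to compound 4 in this assay is expected to be a number 10 percentage points higher from compound 3 to compound 4 (within the scatter), a modest rise within or just beyond the scatter. Compound 4 is therefore estimated at 30%, with a range from 5% to 60%.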

Compound 4, a percentage reported as inhibition, at one concentration (the size of the read-out at that concentration, not a potency): 95%
Beside the measured number, compound 4's estimate is 65 percentage points below it; measured number outside the range, above it.
By their numbers in this assay, from the lowest: compound 2; then compound 3; then compound 1; then compound 4.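

In this assay, putting 4-carboxybenzyl in place of 3-carboxyphenyl on the amide-type nitrogen gives a number 75 percentage points higher from compound 3 to compound 4 (beyond the scatter) and marks this as a large step. The position is therefore highly sensitive to this change, even though both groups have one six-membered aromatic ring of carbon only and the same counts of hydrogen-bond donors and acceptors. Nothing measured here explains why the step is so large.

The swap changes two things at once, phenyl to benzyl and 3-carboxy to 4-carboxy, so the compounds shown cannot say which one carries the step; a 3-carboxybenzyl group on the same nitrogen would separate the two. Also open, from the compounds shown here alone, is whether the carboxylic acid on this group is needed at all, which a plain benzyl group in its place would test.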